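Compound 2 to compound 3: a benzamido swap

A few compounds are considered here, and "the series" means these few. Any claim that something is new, unique, unknown or untested is made for them only; others in the source may bear on it.

In a functional assay on HepG2 cells (Homo sapiens) for cytotoxicity, read by MTT assay, with a stated time of 72 h (on this read-out lower numbers stand for stronger inhibition and higher numbers for weaker inhibition), compound 1 `CN1CCN(c2ccc(Nc3ncc4nc(Nc5cccc([N+](=O)[O-])c5)n(C5CCCC5)c4n3)cc2)CC1` gives > 5000 nM, which is a limit and not a number. Compound 2 `CN1CCN(c2ccc(Nc3ncc4nc(Nc5cccc(C(=O)Nc6ccc(Cl)cc6)c5)n(C5CCCC5)c4n3)cc2)CC1` gives > 5000 nM, which is also a limit. For the measured compounds named here, compound 2 therefore has no numerical position, and the only other value is likewise a limit. Compound 3 `CN1CCN(c2ccc(Nc3ncc4nc(Nc5cccc(NC(=O)c6ccccc6)c5)n(C5CCCC5)c4n3)cc2)CC1` comes next: benzamido in place of (4-chlorophenyl)carbamoyl on an aromatic carbon. The change is benzamido in place of (4-chlorophenyl)carbamoyl on an aromatic carbon, meta to a large group. Going by the values given here, the one measured step bearing on it is a step that the two limits leave unreadable from compound 1 to compound 2, so no size carries over. Among the compounds with values here, with the limit of > 5000 nM in this assay, at which 2 of the 2 values shown sit, as the only evidence, no step of defined size or direction is expected, and another limit is the likeliest report. The expected change is a step that the limit leaves unreadable from compound 2 to compound 3. For compound 3 the estimate is 7000 nM, with an expected range of 3000 nM to 15000 nM.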

Compound 3, half-maximal inhibitory concentration: 2600 nM
Compound 3: middle estimate off by 2.7-fold (0.43 log units), on the high side; measured number outside the range, below it.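

In this assay compound 3 gives 2600 nM, a number and not a limit, so a group at this place on the aromatic ring can give a reading inside the range of the assay. Going by these compounds, the swap reads as an at least 1.9-fold lower number from compound 2 to compound 3 (0.28 log units; that floor lies within the scatter), and the change from nitro reads as an at least 1.9-fold lower number from compound 1 to compound 3 (0.28 log units; that floor lies within the scatter); both are floors, so the true sizes remain unknown, and the step between the two limits cannot be read. Compound 3 is the only compound shown with a number, and the other two sit at a limit: the limit of > 5000 nM in this assay, at which 2 of the 3 values shown sit.

Benzamido and (4-chlorophenyl)carbamoyl differ in both the amide linkage and the chlorine, so the compounds shown do not separate these two changes. Also open, on these data alone, is how 4-chlorobenzamido or a plain amine would read at this place.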